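The source may report more compounds than this note shows. Statements on the series, on what has been measured and on what is new or still open speak of the compounds shown alone.

Compound 1 `Cc1ccc(-c2n[nH]c3c2CCNCC3)cc1` — > 10000 nM
Compound 2 `Cc1ccc(-c2noc3c2CCNCC3)cc1` — > 10000 nM
Compound 3 `Clc1ccc(-c2noc3c2CCNCC3)cc1` — > 10000 nM

In an assay on cells for displacement of a labelled ligand from 5-hydroxytryptamine receptor 1B (Homo sapiens), read by scintillation counting, with a stated time of 1.5 h (on this read-out higher numbers stand for weaker inhibition and lower numbers for stronger inhibition), compound 1 gives > 10000 nM, which is a limit of the assay rather than a number. Compound 2 likewise gives only a limit, > 10000 nM, in this assay. Compound 3 also gives a limit, > 10000 nM. As far as these compounds go, all three values therefore sit at the limit of > 10000 nM in this assay, at which 3 of the 3 values shown sit, so nothing places compound 1 above or below its two companions; where it truly stands is unknown. Compound 2 and compound 3 differ by one change on their shared core, and the step that the two limits leave unreadable from compound 2 to compound 3 cannot be read because both ends are limits.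

Compound 4 `Clc1ccc(-c2n[nH]c3c2CCNCC3)cc1` has not yet been measured in this assay. It differs from compound 1 by chloro in place of methyl on an aromatic carbon. For the measured compounds named here, the only measured step bearing on this change is the one from compound 2 to compound 3, which carries the same exchange on a closely related core; its size is not readable, so it gives no direction. No pattern beyond these three compounds is claimed.

Compound 4 is therefore expected to give 25000 nM in this assay, with a range from 7000 nM to 150000 nM. The step that the limit leaves unreadable from compound 1 to compound 4 is thus expected to be unreadable, most likely ending at the same limit.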

Compound 4, inhibition constant: > 10000 nM
Compound 4: a limit, no number (the forecaster's own chance of this, stated with the estimate: 85%); the middle value is on the limit's open side.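

Compound 4 gives > 10000 nM in this assay, which is a limit and not a number. The step from compound 1 to compound 4 therefore cannot be read, and all values stand together: the limit of > 10000 nM in this assay, at which 4 of the 4 values shown sit. The compounds shown leave open how strong the inhibition of any of them truly is in this assay, and whether chloro in place of methyl changes it.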